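Compound 3 to compound 4: phenyl for pyridin-2-yl

This account rests on a few compounds, and the source may have more. Where it says the series, first, only, none or still open, it means among the compounds named here.

In a physicochemical assay for solubility, using the shake flask method, in phosphate buffer, with a stated time of 24 h, at pH 7.4 (a higher number here means a more soluble compound, a lower number a less soluble compound), compound 3 `CC(Sc1nc2nn(C3COC3)cc2c(=O)n1-c1ccccc1)c1ccccn1` gives 60000 nM and stands second highest of three numbers. Compound 2 `Cn1ncc2c(=O)n(-c3ccccc3)c(CCc3cccc(F)c3)nc21` gives 126000 nM as the highest and compound 1 `O=c1c2cn(C3COC3)nc2nc(SCc2cccc(F)c2)n1-c1ccccc1` gives 5000 nM as the lowest. Compound 4 `CC(Sc1nc2nn(C3COC3)cc2c(=O)n1-c1ccccc1)c1ccccc1` has phenyl in place of pyridin-2-yl on a saturated chain carbon bound to a saturated chain carbon and a sulfur. For the measured compounds named here, one measured step bears on this and it is large (a 12-fold higher number from compound 1 to compound 3 (1.08 log units; beyond the scatter)) with 1-(pyridin-2-yl)ethyl in place of 3-fluorobenzyl on a sulfur. Going by the values given here, no measured pair sets phenyl directly against pyridin-2-yl. Part of that step is expected to be lost, so a lower number is expected (a 4.0-fold lower number from compound 3 to compound 4 (0.60 log units; beyond the scatter)) in this assay. The estimated value for compound 4 is 15000 nM within an expected range from 5000 nM to 40000 nM overall.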

Compound 4, solubility: 26000 nM
Compound 4: middle estimate off by 1.7-fold (0.24 log units), on the low side, and the stated range covers the measured number.
By their numbers in this assay, from the lowest: compound 1; then compound 4; then compound 3; then compound 2.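

In this assay, phenyl in place of pyridin-2-yl gives (a 2.3-fold lower number from compound 3 to compound 4 (0.36 log units; beyond the scatter)), so the nitrogen of pyridin-2-yl does count at this position. Even so, 1-phenylethyl in place of 3-fluorobenzyl on a sulfur still gives (a 5.2-fold higher number from compound 1 to compound 4 (0.72 log units; beyond the scatter)), so a higher number than that of compound 1 does not depend on that nitrogen. No measurement available here explains either step.

Still open, going by these compounds, is whether the higher number follows the chain methyl or the loss of fluorine, which 1-(3-fluorophenyl)ethyl would separate. Also open, on these data alone, is how an amine on the phenyl would read.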